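Aryl-piperazine variation in the shared thiophene series: third analogue

The source may hold more compounds than are shown below. What is called first, only, known or untested is meant among the compounds shown, and "the series" means these compounds.

Measured so far:
compound 1 `Nc1scc(CN2CCN(c3ccc(Cl)c(C(F)(F)F)c3)CC2)c1C(=O)c1ccc(Cl)cc1` — 3%
compound 2 `Nc1scc(CN2CCN(c3c(F)cc(F)cc3F)CC2)c1C(=O)c1ccc(Cl)cc1` — 0%

Both measured compounds of the series have been run in an assay on CHO cells for displacement of a labelled ligand from adenosine receptor A3 (Homo sapiens), read by scintillation counting, with a stated time of 120 min, tested at 10 uM; on this read-out lower numbers stand for less inhibition and higher numbers for more inhibition at the one concentration tested (going by the name of the read-out). Compound 1 gives 3% in this assay. Within the data shown here, compound 2 gives 0% in this assay, the lowest of the two numbers, with compound 1 as its nearest neighbour; the one measured step, a number 3 percentage points lower from compound 1 to compound 2 (within the scatter), lies within the scatter, so the two values are not distinguished.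

Compound 3 `Nc1scc(CN2CCN(c3ccc(F)c(Cl)c3)CC2)c1C(=O)c1ccc(Cl)cc1` is not yet measured. Its difference from compound 2 is 3-chloro-4-fluorophenyl in place of 2,4,6-trifluorophenyl on an amine nitrogen in a ring. Among the measured compounds shown here, the only step that bears on this change is the one from compound 1 to compound 2, which also replaced the group on the same ring nitrogen and produced no movement beyond the scatter. With both measured values close to the floor of the read-out, compound 3 is expected to give a step of a number 3 percentage points higher from compound 2 to compound 3 (within the scatter), that is none beyond the scatter. The estimate for compound 3 is 3%, with a range from -6% to 14%.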

Compound 3, a percentage reported as inhibition, at one concentration (the size of the read-out at that concentration, not a potency): 0%
Estimate against measurement, compound 3: 3 percentage points above; the measured number falls inside the stated range.
By their numbers in this assay, from the lowest: compounds 2, 3 and 1 (each within the scatter of the next).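

In this assay, putting 3-chloro-4-fluorophenyl on the amine nitrogen in a ring gives no change at the digits printed from compound 2 to compound 3 (within the scatter) and gives a number 3 percentage points lower from compound 1 to compound 3 (within the scatter). Among these compounds, this position now carries three different halogen-bearing phenyl groups, with one, three and two ring substituents in the three compounds, and no pair among them is separated beyond the scatter at the one concentration tested, so the change of substituents seen here has not yet produced any readable difference. No measurement is at hand that would account for these numbers.

All three groups on this nitrogen are halogen-bearing phenyl rings, so the compounds shown leave open whether a phenyl ring carrying a methoxy group, an amine or a carboxylic acid would give a number beyond the scatter in this assay. As far as these compounds go, the rest of the shared core is the same in all three compounds, so what a change elsewhere, for example at the 4-chlorophenyl on the carbonyl, would do in this read-out also stays open.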